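Notes on the step from compound 2 to compound 3

The source may report more compounds than this note shows. Statements on the series, on what has been measured and on what is new or still open speak of the compounds shown alone.

- compound 1 `CCNc1ccc(NC(=O)c2cc(Cl)ccc2O)c(Cl)c1`: 30200 nM
- compound 2 `O=C(Nc1ccc(NCc2ccc(F)cc2)cc1Cl)c1cc(Cl)ccc1O`: 54400 nM

In an ADME assay on A549 cells (Homo sapiens) for cytotoxicity, read by resazurin assay, with a stated time of 48 h (on this read-out higher numbers stand for lower toxicity in this test and lower numbers for higher toxicity in this test), compound 2 gives 54400 nM, which lies within the scatter of compound 1, so neither stands apart from the other. Compound 3 `O=C(Nc1ccc(NCc2ccc(C(F)(F)F)cc2)cc1Cl)c1cc(Cl)ccc1O` differs from compound 2 by trifluoromethyl in place of fluoro on an aromatic carbon, para to a large group. For the measured compounds named here, only one measured step bears on this change, and it is indirect. The step of a 1.8-fold higher number from compound 1 to compound 2 (0.26 log units; within the scatter) brought in the 4-fluorophenyl in place of methyl and stayed within the scatter. Going by the values given here, no measured step varies the group on that ring itself. On this thin evidence, no step beyond the scatter is expected in this assay. The expected step is a 1.2-fold lower number from compound 2 to compound 3 (0.08 log units; within the scatter). Compound 3 is estimated at 45000 nM, with an expected range from 18000 nM to 100000 nM.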

Compound 3, half-maximal cytotoxic concentration: 62700 nM
The estimate for compound 3 lay 1.4-fold (0.14 log units) below the measured number, and the stated range covers the measured number.
By their numbers in this assay, from the lowest: compounds 1, 2 and 3 (each within the scatter of the next, the first and the last beyond it).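

In this assay, trifluoromethyl in place of fluoro on this aromatic carbon, para to a large group, gives a 1.2-fold higher number from compound 2 to compound 3 (0.06 log units; within the scatter), so the compounds shown do not tell these two groups apart at this position. Set against the methyl end of compound 1, the 4-(trifluoromethyl)phenyl group gives a 2.1-fold higher number from compound 1 to compound 3 (0.32 log units; beyond the scatter), the only step here beyond the scatter and a modest one, whereas the 4-fluorophenyl group stayed within it. Nothing at hand accounts for either step.

Going by these compounds, whether an amine or a carboxylic acid on this aromatic carbon would stay within the same range remains open. Also open, on these data alone, is whether a longer chain carrying the 4-(trifluoromethyl)phenyl group on that nitrogen would extend or lose the step seen from compound 1.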